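Series notes: a chloro step from compound 2 to compound 3

The source may report more compounds than this note shows. Statements on the series, on what has been measured and on what is new or still open speak of the compounds shown alone.

In a functional assay on HepG2 cells (Homo sapiens) for inhibition, read by MTT assay, with a stated time of 24 h, tested at 5 uM (on this read-out lower numbers stand for less inhibition of growth and higher numbers for more inhibition of growth at the one concentration tested), compound 2 `CS(=O)(=O)c1ccc(-c2cnc3[nH]cc(-c4nnc(-c5ccccc5)o4)c(=O)c3c2)cc1` gives 5.46% and stands at the upper of the two numbers shown, though compound 1 `CS(=O)(=O)c1ccc(-c2cnc3[nH]cc(-c4nnc(-c5ccncc5)o4)c(=O)c3c2)cc1`, which gives 3.49%, lies within its scatter: the step of a number 2 percentage points higher from compound 1 to compound 2 (within the scatter). Compound 3 `CS(=O)(=O)c1ccc(-c2cnc3[nH]cc(-c4nnc(-c5ccc(Cl)cc5)o4)c(=O)c3c2)cc1` carries the change (chloro in place of hydrogen on an aromatic carbon), chloro in place of hydrogen on an aromatic carbon, para to a large group. Within the data shown here, only the step of a number 2 percentage points higher from compound 1 to compound 2 (within the scatter) bears on this ring, and it stayed within the scatter, so no step beyond the scatter is expected in this assay. Compound 3 is therefore estimated at 6%, between -3% and 16%. The expected step is a number 0.5 percentage points higher from compound 2 to compound 3 (within the scatter).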

Compound 3, percent growth inhibition at one concentration: 11.3%
The estimate for compound 3 lay 5.3 percentage points below the measured number, and the stated range covers the measured number.
By their numbers in this assay, from the lowest: compounds 1, 2 and 3 (each within the scatter of the next).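

Working notes: in this assay, the phenyl to 4-chlorophenyl change at the position para to a large group gives a number 5.8 percentage points higher from compound 2 to compound 3 (within the scatter). The change from pyridin-4-yl to 4-chlorophenyl gives a number 7.8 percentage points higher from compound 1 to compound 3 (within the scatter), so the three groups at this site remain within the scatter of one another, and neither change separates from it. Nothing on hand accounts for these numbers.

On these data alone, whether an amine or a carboxylic acid at this same position would give a step beyond the scatter remains open. So does the outcome for a longer chain there.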